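From Methyl to Butoxy: A Step Still Unmeasured

This account rests on a few compounds, and the source may have more. Where it says the series, first, only, none or still open, it means among the compounds named here.

Measured so far in a functional assay on L1210 cells (Mus musculus) for cytotoxicity, read by MTT assay, with a stated time of 24 h; on this read-out higher numbers stand for weaker inhibition and lower numbers for stronger inhibition:
- compound 1 `COc1cc(C(=O)/C=C/c2ccc3ccccc3c2)ccc1O` gives 54000 nM
- compound 2 `COc1cc(C(=O)/C=C/c2ccc(Cl)c(Cl)c2)cc(OC)c1OC` gives 44000 nM
- compound 3 `COc1cc(C(=O)/C=C/c2ccc(C)cc2)cc(OC)c1OC` gives 50500 nM

Compound 3 gives 50500 nM in this assay and lies within the scatter of both compound 1 and compound 2, so the three values show no order. Compound 4 `CCCCOc1ccc(/C=C/C(=O)c2cc(OC)c(OC)c(OC)c2)cc1` has butoxy in place of methyl on an aromatic carbon, para to a large group (butoxy in place of methyl on an aromatic carbon). Within the data shown here, the one measured step bearing on this change is a 1.1-fold higher number from compound 2 to compound 3 (0.06 log units; within the scatter) and it stays within the scatter. Among the measured compounds shown here, no measured compound carries butoxy, so the data give no direction, and no step beyond the scatter is expected. The estimated step is a 1.1-fold lower number from compound 3 to compound 4 (0.05 log units; within the scatter) and it rests on that single comparison. For compound 4 the estimate is 45000 nM with an expected range of 20000 nM to 90000 nM in this read-out.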

Compound 4, half-maximal inhibitory concentration: > 100000 nM
Compound 4: only a limit was reported (the forecaster's own chance of this, stated with the estimate: 10%); middle value at least 2.2-fold (0.34 log units) from the limit.
By their numbers in this assay, from the lowest: compounds 2, 3 and 1 (each within the scatter of the next). At a limit, above all of these: compound 4.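

In this assay compound 4 gives > 100000 nM, which is a limit of the assay and not a number. Butoxy in place of methyl on this aromatic carbon, para to a large group, gives an at least 1.9-fold higher number from compound 3 to compound 4 (0.29 log units; that floor lies within the scatter), so the floor of this step does not leave the scatter. Among the compounds shown, only this change ends at a limit: the limit of > 100000 nM in this assay, at which 1 of the 4 values shown sits.

As far as these compounds go, how far compound 4 lies past its limit remains open. So does whether ethoxy or an amine at this position would stay close to compound 3.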